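Swapping a Ring Amine for Two Open Chains

The source may report more compounds than this note shows. Statements on the series, on what has been measured and on what is new or still open speak of the compounds shown alone.

Measured so far:
- compound 1, `NS(=O)(=O)Oc1ccc2c(c1)CN(C(=O)c1ccc(N3CCCCC3)cc1)CC2`: 38.3%
- compound 2, `CCN(Cc1ccccn1)c1cccc(C(=O)N2CCc3ccc(OS(N)(=O)=O)cc3C2)c1`: 19.9%
- compound 3, `CN(C)CCCN(Cc1ccccc1)c1cccc(C(=O)N2CCc3ccc(OS(N)(=O)=O)cc3C2)c1`: 26%

Three compounds share a core and differ only in the amine attached to the benzoyl part. In an assay on HEK293 cells for inhibition of Steryl-sulfatase (Homo sapiens), tested at 1 uM (on this read-out higher numbers stand for a stronger effect at the one concentration tested and lower numbers for a weaker effect), compound 1 gives 38.3%, the highest of the three numbers; compound 3 gives 26% and compound 2 gives 19.9%, both lower by more than the usual scatter. Among the measured compounds shown here, no pair here differs in just one place, so no single step can be traced between them.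

On these data alone, compound 4, `CC(C)CCN(CCC(C)C)c1ccc(C(=O)N2CCc3ccc(OS(N)(=O)=O)cc3C2)cc1`, is untested. Compared with compound 1 the change is diisopentylamino in place of piperidin-1-yl on an aromatic carbon: a ring amine gives way to a larger open-chain one on an aromatic carbon of a six-membered aromatic ring of carbon only. For the measured compounds named here, with no directly comparable step available, the expected step of a number 8.3 percentage points lower from compound 1 to compound 4 (within the scatter) in this assay is a small to moderate decrease, not clearly beyond the scatter. Compound 4 is therefore estimated at 30% in this assay, with a range from 10% to 52%.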

Compound 4, a percentage reported as inhibition, at one concentration (the size of the read-out at that concentration, not a potency): 90.8%
Compound 4: the middle estimate sits 60.8 percentage points below what was measured; the whole stated range lies below it.
By their numbers in this assay, from the lowest: compounds 2 and 3 (each within the scatter of the next); then compound 1; then compound 4.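

In this assay, among the compounds shown here, putting diisopentylamino in place of piperidin-1-yl on an aromatic carbon, para to a large group, gives a number 52.5 percentage points higher from compound 1 to compound 4 (beyond the scatter), the first single change that can be read in this set. It shows that this position accepts an open-chain amine with 11 heavy atoms and no ring in place of a ring amine with 6, while the counts of hydrogen-bond donors and acceptors and the net charge stay the same. No measurement shown explains the rise.

On these data alone, it remains open whether the rise comes from opening the ring or from the added heavy atoms. Diethylamino, a shorter open-chain amine, and azepan-1-yl, a larger ring amine, at this same position would help separate the two.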